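This account rests on a few compounds, and the source may have more. Where it says the series, first, only, none or still open, it means among the compounds named here.

Working notes on the series. Compound 1 `COc1cc2c(Oc3ccc(NC(=O)N/N=C/c4ccc(Cl)cc4Cl)cc3F)ccnc2cc1OCCCN1CCCCC1` and compound 2 `COc1cc2c(Oc3ccc(NC(=O)N/N=C/c4ccc(OC(F)(F)F)cc4)cc3F)ccnc2cc1OCCCN1CCCCC1` share one core and differ only in the aryl group on the carbon double-bonded to nitrogen; in a functional assay on MDA-MB-231 cells (Homo sapiens) for cytotoxicity, read by MTT assay, with a stated time of 72 h (a lower number here means a stronger inhibitor, a higher number a weaker inhibitor), compound 1 gives 750 nM and compound 2 gives 820 nM, a step of a 1.1-fold higher number from compound 1 to compound 2 (0.04 log units; within the scatter). Compound 3 `COc1ccc(/C=N/NC(=O)Nc2ccc(Oc3ccnc4cc(OCCCN5CCCCC5)c(OC)cc34)c(F)c2)c(OC)c1` was run in this assay, where compound 3 gives "not determined" (no result reported), so its standing is open. Compound 4 `COc1cc2c(Oc3ccc(NC(=O)N/N=C/c4ccc(O)cc4)cc3F)ccnc2cc1OCCCN1CCCCC1` differs from compound 3 as follows: 4-hydroxyphenyl in place of 2,4-dimethoxyphenyl on a carbon with a double bond to nitrogen. Going by the values given here, no measured step covers an exchange of this kind; the one measured aryl exchange, a 1.1-fold higher number from compound 1 to compound 2 (0.04 log units; within the scatter), stayed within the scatter, and compound 3 offers no anchor. On compounds 1 and 2 alone, compound 4 is expected in this assay near 800 nM, plausibly between 300 nM and 2500 nM.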

Compound 4, half-maximal inhibitory concentration: 790 nM
The estimate for compound 4 lay 1.0-fold (0.01 log units) above the measured number, and the stated range covers the measured number.
By their numbers in this assay, from the lowest: compounds 1, 4 and 2 (each within the scatter of the next).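

At the carbon with a double bond to nitrogen, 4-hydroxyphenyl, with its hydrogen-bond donor, gives no step beyond the scatter in this assay against either earlier aryl group: a 1.0-fold lower number from compound 2 to compound 4 (0.02 log units; within the scatter) and a 1.1-fold higher number from compound 1 to compound 4 (0.02 log units; within the scatter). Going by these compounds alone, compounds 1, 2 and 4 therefore read alike here, extending the one earlier flat exchange to a third aryl group. Nothing at hand explains this flat reading.

Steps to compound 3 cannot be read, so 2,4-dimethoxyphenyl remains unplaced. From the compounds shown here alone, whether an amine or a carboxylic acid in place of the hydroxyl would hold this level remains open.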